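This account rests on a few compounds, and the source may have more. Where it says the series, first, only, none or still open, it means among the compounds named here.

Compound 1 `O=C(O)c1ccc(S(=O)(=O)Nc2ccc(NS(=O)(=O)c3ccc(F)cc3)cc2)cc1` gives in an assay for inhibition of liver carboxylesterase 1 (Homo sapiens), read by spectrophotometry (a higher number here means a weaker inhibitor, a lower number a stronger inhibitor), only the limit > 100000 nM.
Compound 2 `Cc1ccc(S(=O)(=O)Nc2ccc(NS(=O)(=O)c3ccc(F)c(F)c3)cc2)cc1` gives in this assay only the limit > 100000 nM.
Compound 3 `O=S(=O)(Nc1ccc(NS(=O)(=O)c2ccc(F)cc2)cc1)c1ccc(F)cc1` gives in this assay only the limit > 100000 nM.

Compound 3 therefore stands at the limit of this assay, where the limit of > 100000 nM in this assay, at which 3 of the 3 values shown sit, places every measured compound; no number is known for it. Within the data shown here, the one measured step that touches its position, a step that the two limits leave unreadable from compound 1 to compound 3, cannot be read because both ends sit at that limit. Compound 4 `CNC(=O)c1ccc(S(=O)(=O)Nc2ccc(NS(=O)(=O)c3ccc(F)cc3)cc2)cc1` differs from compound 3 by methylcarbamoyl in place of fluoro on an aromatic carbon. Since carboxy and fluoro at this place both leave this assay at its limit, the methylcarbamoyl is expected to do the same, and the step that the limit leaves unreadable from compound 3 to compound 4 is expected to be none beyond the scatter. Compound 4 is estimated at 200000 nM, with a range from 50000 nM to 1000000 nM, most likely reported again only as a limit.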

Compound 4, inhibition constant: > 100000 nM
Compound 4: only a limit was reported; the forecaster's own chance of this, stated with the estimate: 85%; the middle value is on the limit's open side.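

In this assay compound 4 gives > 100000 nM as a limit only. Among these compounds, no step among compound 1, compound 3 and compound 4 can be read, since all sit at one limit: the limit of > 100000 nM in this assay, at which 4 of the 4 values shown sit. The compounds shown leave open which change to the shared core, if any, would give a readable value in this assay at all.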